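Replacing 4-Chlorophenyl with 1,2-Oxazol-5-yl on the Amide

This account rests on a few compounds, and the source may have more. Where it says the series, first, only, none or still open, it means among the compounds named here.

The series shares one core carrying an amide, and its members differ only in the group on the carbonyl carbon. Compound 1 `COc1ccc(-c2cnc(NC(=O)c3cccc(C#N)c3)n2C)cc1` carries 3-cyanophenyl there. In a toxicity assay on THP-1 cells (Homo sapiens) for inhibition (on this read-out lower numbers stand for higher toxicity in this test and higher numbers for lower toxicity in this test), compound 1 reaches only the limit of the test, > 100000 nM. Compound 2 `COc1ccc(-c2cnc(NC(=O)c3ccccc3Br)n2C)cc1` carries 2-bromophenyl; in this assay compound 2 also sits at a limit, > 100000 nM. Compound 3 `COc1ccc(-c2cnc(NC(=O)c3ccc(Cl)cc3)n2C)cc1` carries 4-chlorophenyl, and in this assay compound 3 likewise gives a limit, > 100000 nM. Because of the limit of > 100000 nM in this assay, at which 3 of the 3 values shown sit, none of the steps can be sized: a step that the two limits leave unreadable from compound 1 to compound 2, a step that the two limits leave unreadable from compound 1 to compound 3 and a step that the two limits leave unreadable from compound 2 to compound 3 stay unreadable. Compound 3 thus stands where its two companions stand.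

Compound 4 `COc1ccc(-c2cnc(NC(=O)c3ccno3)n2C)cc1` brings the first move away from a six-membered ring: 1,2-oxazol-5-yl in place of 4-chlorophenyl on a carbonyl carbon. Going by the values given here, no measured step shows how such a swap moves the read-out; the three readings show only that these amides have not reached a measurable cytotoxic concentration. Compound 4 is therefore expected to stay near the limit, with an expected step of a number no higher from compound 3 to compound 4 (the limit leaves the size open). For compound 4 the estimate in this assay is 100000 nM, with a range from 50000 nM to 300000 nM.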

Compound 4, half-maximal cytotoxic concentration: > 100000 nM
Compound 4: a limit, no number; the forecaster's own chance of this, stated with the estimate: 80%; the middle value sits exactly at the limit.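

Going by these compounds alone, no step from compound 1, compound 2 or compound 3 to compound 4 can be sized, because the readings offer no number to compare: the limit of > 100000 nM in this assay, at which 4 of the 4 values shown sit.

The compounds shown leave open how far these four amides differ in this assay, and what group on the carbonyl carbon would bring a measurable cytotoxic concentration.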